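Dropping the Fluorine from the Benzoyl Group of Compound 1

This account rests on a few compounds, and the source may have more. Where it says the series, first, only, none or still open, it means among the compounds named here.

Measured compounds:
compound 1 `O=C(NCc1ccc(CNS(=O)(=O)c2ccccc2)cc1)c1ccc(F)cc1` — 100 nM
compound 2 `Cc1ccc(S(=O)(=O)NCc2ccc(CNC(=O)c3ccccc3Cl)cc2)cc1` — 10 nM
compound 3 `Cc1ccc(S(=O)(=O)NCc2ccc(CNC(=O)c3c(Cl)cc(Cl)cc3Cl)cc2)cc1` — 10 nM

In an assay on MDA-MB-231 cells for binding affinity to C-X-C chemokine receptor type 4 (Homo sapiens), read by immunofluorescence and microscopy, with stated times of 10 min and 30 min (a lower number here means that less compound is needed, a higher number that more compound is needed for the effect), compound 1 gives 100 nM, the highest of the three numbers; compound 2 and compound 3 both stand lower, beyond the scatter. Within the data shown here, the one measured step, no change at the digits printed from compound 2 to compound 3 (within the scatter), shows that altering the chlorine pattern on the carbonyl-bearing ring left the number where it was. Compound 4 `O=C(NCc1ccc(CNS(=O)(=O)c2ccccc2)cc1)c1ccccc1` differs from compound 1 by hydrogen in place of fluoro on an aromatic carbon. Among the measured compounds shown here, no measured pair removes a lone fluoro, so that step is the only guide, and it points to little movement. Compound 4 is therefore expected to stay near compound 1, no change at the digits printed from compound 1 to compound 4 (within the scatter). The estimate for compound 4 is 100 nM, within 40 nM to 250 nM.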

Compound 4, effective concentration (reported as EC, without a stated level of effect): 1 nM
Compound 4: the middle estimate sits 100-fold (2.00 log units) above what was measured, outside the stated range (below it).
By their numbers in this assay, from the lowest: compound 4; then compounds 2 and 3 (each within the scatter of the next); then compound 1.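

In this assay this position proves highly sensitive, with a large step of a 100-fold lower number from compound 1 to compound 4 (2.00 log units; beyond the scatter) on replacing fluoro with hydrogen para to a large group. The flat step no change at the digits printed from compound 2 to compound 3 (within the scatter) involved a different substitution in a different pair, and its result does not carry over to this change. Nothing shown here accounts for the size of the step.

On these data alone, it remains open whether a chlorine, a methoxy group or an amine at this place would match hydrogen or fluoro. As far as these compounds go, it also remains open whether the same exchange would matter as much with a methyl group on the sulfonyl-bearing ring.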